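Replacing the aryl ether of compound 1 with a thioether

The source may report more compounds than this note shows. Statements on the series, on what has been measured and on what is new or still open speak of the compounds shown alone.

Measured compounds:
compound 1 `Nc1cc(N)c2nc(-c3ccccc3)c(Oc3ccc(Cl)c(Cl)c3)nc2c1`: < 100000 nM
compound 2 `COc1ccc(CNc2nc3cc(N)cc(N)c3nc2-c2ccccc2)cc1OC`: 100000 nM
compound 3 `COc1ccc(CNc2nc3cc(N)cc(N)c3nc2-c2ccccc2)cc1`: < 100000 nM

In a functional assay on NCI-H322M cells (Homo sapiens) for inhibition, read by sulforhodamine B assay, with a stated time of 48 h (a higher number here means that more compound is tolerated, a lower number that less compound is tolerated), compound 1 reaches only a limit, < 100000 nM. Compound 2 gives 100000 nM in this assay. For compound 3 this assay again stops at a limit, < 100000 nM. Among the measured compounds shown here, the one change measured within the set, from compound 2 to compound 3, gives a number no higher from compound 2 to compound 3 (the limit leaves the size open), so its size is not readable. Compound 4 `COc1ccc(Sc2nc3cc(N)cc(N)c3nc2-c2ccccc2)cc1` is not yet measured; it differs from compound 1 by (4-methoxyphenyl)sulfanyl in place of 3,4-dichlorophenoxy on an aromatic carbon. For the measured compounds named here, no measured step covers this change, and the set sits at the limit of < 100000 nM in this assay, at which 2 of the 3 values shown sit, so no direction can be read. Compound 4 is therefore expected near the same level, 80000 nM, with a range of 20000 nM to 150000 nM. The expected step is a step that the limit leaves unreadable from compound 1 to compound 4.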

Compound 4, concentration lethal to 50% of the cells: < 100000 nM
Compound 4: a limit, no number; the forecaster's own chance of this, stated with the estimate: 60%; the middle value lies beyond the limit too.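

In this assay compound 1 and compound 4 both stop at a limit, so the step between them cannot be read: the limit of < 100000 nM in this assay, at which 3 of the 4 values shown sit.

The compounds shown leave open whether (4-methoxyphenyl)sulfanyl in place of 3,4-dichlorophenoxy changes the read-out at all.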